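Notes on the ester-side change toward compound 3

A few compounds are considered here, and "the series" means these few. Any claim that something is new, unique, unknown or untested is made for them only; others in the source may bear on it.

Within the data shown here, compound 2 `CCOc1cc(NC(=O)C2(NC(=O)c3ccc4c(C5CCCC5)c(-c5ncc(Cl)cn5)n(C)c4c3)CCC2)ccc1/C=C/C(=O)OCC(=O)OC` gives 2.08 h in an ADME assay (liver) for pharmacokinetics, with Liver microsome (Rattus norvegicus) as the target, using microsomes (a higher number here means that the compound lasts longer, a lower number that the compound disappears faster), the lowest of the two numbers measured so far, with its nearest neighbour compound 1 `CCOc1cc(NC(=O)C2(NC(=O)c3ccc4c(C5CCCC5)c(-c5ncc(Cl)cn5)n(C)c4c3)CCC2)ccc1/C=C/C(=O)OCc1ccccc1` at 2.17 h in this assay. Among the measured compounds shown here, both share the same core, and the only change between them was a 1.0-fold lower number from compound 1 to compound 2 (0.02 log units; within the scatter), a step within the scatter. Compound 3 `CCOc1cc(NC(=O)C2(NC(=O)c3ccc4c(C5CCCC5)c(-c5ncc(Cl)cn5)n(C)c4c3)CCC2)ccc1/C=C/C(=O)OCC(=O)N1CCOCC1` is not yet measured. It differs from compound 2 by morpholin-4-yl in place of methoxy on a carbonyl carbon, a change on the same chain that was varied between compound 1 and compound 2. For the measured compounds named here, the one measured step sits on that chain but exchanges a different group, and bears on the new change only loosely; because a 1.0-fold lower number from compound 1 to compound 2 (0.02 log units; within the scatter) stayed within the scatter, no step beyond the scatter is expected for a 1.0-fold lower number from compound 2 to compound 3 (0.02 log units; within the scatter). Compound 3 is therefore estimated at 2 h in this assay, with a range of 1 h to 4 h.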

Compound 3, half-life: 0.733 h
The estimate for compound 3 lay 2.7-fold (0.44 log units) above the measured number; the whole stated range lies above it.
By their numbers in this assay, from the lowest: compound 3; then compounds 2 and 1 (each within the scatter of the next).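

On this chain, the group on the carbonyl carbon does register in this assay: morpholin-4-yl in place of methoxy gives a 2.8-fold lower number from compound 2 to compound 3 (0.45 log units; beyond the scatter), whereas the earlier exchange on the same chain gave only a 1.0-fold lower number from compound 1 to compound 2 (0.02 log units; within the scatter). Measured against the phenyl end, (morpholin-4-yl)carbonyl gives a 3.0-fold lower number from compound 1 to compound 3 (0.47 log units; beyond the scatter), so compound 3 lies below both other compounds, which remain within the scatter of each other. Nothing available explains this step.

The compounds shown do not separate the morpholine ring from the simple presence of a nitrogen on the carbonyl carbon, a question that a dimethylamino or piperidin-1-yl group would address. They also leave open whether a longer chain carrying the same (morpholin-4-yl)carbonyl group would give a comparable step.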